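Hydroxy to Chloro on a Fused Ring Core

The source may hold more compounds than are shown below. What is called first, only, known or untested is meant among the compounds shown, and "the series" means these compounds.

Compound 2 `CS(=O)(=O)Nc1ccc(O)c2c1CCCC2c1c[nH]cn1` is the lower of the two measured compounds. In a functional assay on Urethra with Alpha-1A adrenergic receptor (Oryctolagus cuniculus) as the target (a higher number here means a larger maximal response, a lower number a smaller maximal response), compound 2 gives 34%, while compound 1 `CC(c1cccc(NS(C)(=O)=O)c1)c1c[nH]cn1` gives 92%, a gap well beyond the scatter. Compound 3 `CS(=O)(=O)Nc1ccc(Cl)c2c1CCCC2c1c[nH]cn1` differs from compound 2 by one change: chloro in place of hydroxy on an aromatic carbon, the chloro arriving where the hydroxy stood, para to the methanesulfonamido group. For the measured compounds named here, no measured pair shows this exchange, so its effect is unknown. The estimated step is a number 16 percentage points higher from compound 2 to compound 3 (beyond the scatter), a modest rise with wide uncertainty. Compound 3 is therefore expected to give 50% in this assay, within 20% to 90%.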

Compound 3, largest response reached (reported as efficacy), in percent of the reference or control that the assay uses: 41%
For compound 3 the middle estimate is 9 percentage points above the measured one; the range from low to high includes it.
By their numbers in this assay, from the lowest: compounds 2 and 3 (each within the scatter of the next); then compound 1.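

At the aromatic carbon para to a methanesulfonamido group, chloro in place of hydroxy gives, in this assay, a number 7 percentage points higher from compound 2 to compound 3 (within the scatter). Compound 2 and compound 3 therefore cannot be told apart, although chloro has 0 hydrogen-bond donors and 0 hydrogen-bond acceptors where hydroxy has 1 of each. No available measurement gives a reason for this result.

The compounds shown leave open whether an amine, a methoxy group or a fluoro at this position would give a response distinct from those of compound 2 and compound 3.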